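Swapping the amine substituent on the shared core

This account rests on a few compounds, and the source may have more. Where it says the series, first, only, none or still open, it means among the compounds named here.

Of the compounds shown here, two sharing one core have been tested. Compound 1 `CCN(CC)Cc1ccc(/C=C2\COc3cc(OC)c(OC)cc3C2=O)cc1O` carries a diethylamino group on the saturated chain carbon bound to an aromatic carbon, and in an assay on isolated protein for inhibition of Amine oxidase [flavin-containing] A (Homo sapiens), read by fluorescence, with a stated time of 30 min, tested at 20 uM (a higher number here means more inhibition at the concentration tested (going by the name of the read-out), a lower number less inhibition), compound 1 gives 9.5%. Compound 2 `COc1ccccc1CN(C)Cc1ccc(/C=C2\COc3cc(OC)c(OC)cc3C2=O)cc1O` carries a (2-methoxybenzyl)(methyl)amino group at that place, and in this assay compound 2 gives 12.3%. Going by the values given here, compound 2 stands highest of the two numbers, but its only neighbour is compound 1, and the step of a number 2.8 percentage points higher from compound 1 to compound 2 (within the scatter) lies within the scatter, so no order between them can be claimed.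

The next compound, compound 3 `CCN(Cc1ccccc1)Cc1ccc(/C=C2\COc3cc(OC)c(OC)cc3C2=O)cc1O`, differs from compound 2 in one place: benzyl(ethyl)amino in place of (2-methoxybenzyl)(methyl)amino on a saturated chain carbon bound to an aromatic carbon. Among the compounds with values here, the only step that bears on this change is the one from compound 1 to compound 2, which also swapped the substituents on that amine and stayed within the scatter. On that basis the step from compound 2 to compound 3 is expected to be a number 1.3 percentage points lower from compound 2 to compound 3 (within the scatter), nothing beyond the scatter. Compound 3 is therefore estimated to give 11% in this assay, with a range from 2% to 22%.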

Compound 3, a percentage reported as inhibition, at one concentration (the size of the read-out at that concentration, not a potency): 15%
Estimate against measurement, compound 3: 4 percentage points below; the range from low to high includes it.
By their numbers in this assay, from the lowest: compounds 1, 2 and 3 (each within the scatter of the next).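

At this position, on a saturated chain carbon bound to an aromatic carbon, benzyl(ethyl)amino in place of (2-methoxybenzyl)(methyl)amino gives in this assay a number 2.7 percentage points higher from compound 2 to compound 3 (within the scatter), so a second swap of the amine substituents, this time one that also loses the methoxy oxygen counted in the group that leaves, again stays within the scatter. Phenyl in place of methyl on a saturated chain carbon bound to an amine nitrogen gives a number 5.5 percentage points higher from compound 1 to compound 3 (within the scatter), and so even the widest gap among the three compounds does not separate a diethylamino group from a benzyl(ethyl)amino group, which leaves the three amines indistinguishable in this assay. No measurement is available that would explain this lack of separation.

The compounds shown leave open whether any replacement at this place can move the number beyond the scatter, for instance a morpholine or a piperidine in place of the open-chain amines, or a carboxylic acid in place of the amine altogether. They also leave open whether a longer chain between the amine nitrogen and the aromatic carbon would do so.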